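The source may hold more compounds than are shown below. What is called first, only, known or untested is meant among the compounds shown, and "the series" means these compounds.

Compound 1 `COc1cccc(OC(=O)c2cc(O)cc(O)c2)c1OC(=O)c1cc(O)cc(O)c1` and compound 2 `O=C(Oc1cccc(F)c1OC(=O)c1cc(O)cc(O)c1)c1cc(O)cc(O)c1` differ in a single place: fluoro in place of methoxy on an aromatic carbon. In a functional assay on NCI-H1299 cells (Homo sapiens) for inhibition, read by scintillation counting, with a stated time of 30 min, tested at 30 uM (a lower number here means less inhibition, a higher number more inhibition at the concentration tested (going by the name of the read-out)), compound 1 gives 69.4%, while compound 2 gives 94%, which amounts to a number 24.6 percentage points higher from compound 1 to compound 2 (beyond the scatter).

Compound 3 `COc1cc(C(=O)Oc2cccc(OC)c2OC(=O)c2cc(OC)c(OC)c(OC)c2)cc(OC)c1OC` is built on a different core; how the core of compound 3 differs from the core of compound 1 is not broken down here. In this assay compound 3 gives 33.3%, the lowest of the three measured numbers, and its gaps to compound 1 and to compound 2 both lie beyond the usual scatter of this kind of measurement.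

Compound 4 `COc1cc(C(=O)Oc2cccc(F)c2OC(=O)c2cc(OC)c(OC)c(OC)c2)cc(OC)c1OC` has not yet been measured. It stands to compound 3 exactly as compound 2 stands to compound 1: fluoro in place of methoxy on an aromatic carbon. The surroundings of the place are described in the same words for both pairs, so this is the same change, occurring twice among the compounds shown.

The expectation for compound 4 rests on a single measured example. Because a number 24.6 percentage points higher from compound 1 to compound 2 (beyond the scatter) was observed on one core, a rise of similar direction is expected on the other core too, though the different core makes the size less certain. For compound 4 the expected step is a number 18.7 percentage points higher from compound 3 to compound 4 (beyond the scatter). In this assay compound 4 is expected to give about 52%, most likely between 30% and 75%.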

Compound 4, a percentage reported as inhibition, at one concentration (the size of the read-out at that concentration, not a potency): 7.9%
For compound 4 the middle estimate is 44.1 percentage points above the measured one; the measured number lies below the stated range.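

In this assay, the swap of methoxy for fluoro did not carry over from one core to the other: on the second core it gives a number 25.4 percentage points lower from compound 3 to compound 4 (beyond the scatter), the opposite direction to the rise seen on the first core. Setting the two steps side by side shows how far apart they are: the same change on two cores in this assay, a number 24.6 percentage points higher (beyond the scatter) from compound 1 to compound 2 and a number 25.4 percentage points lower (beyond the scatter) from compound 3 to compound 4, 50 percentage points apart, beyond the scatter of two such steps

So in this series, the direction of this change depends on the core that carries it, and a step measured on one core is a poor guide to the same step on the other; what the data do not show is which difference between the two cores is responsible, and one pair on each core gives no rule for any further core.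

The compounds shown carry only methoxy or fluoro at this place, so it stays open how a chlorine atom, a nitrile or an amine would behave there on either core. On these data alone, each number here is also a reading at a single concentration, and how these compounds would compare across a range of concentrations remains open too.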